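Moving the fluorine on the aromatic ring of compound 2

The source may hold more compounds than are shown below. What is called first, only, known or untested is meant among the compounds shown, and "the series" means these compounds.

Among the measured compounds shown here, compound 2 `CC(=O)OC/C(=C\c1ccc(F)cc1)C(=O)c1ccccc1` gives 25000 nM in a functional assay on HeLa cells (Homo sapiens) for inhibition, read by sulforhodamine B assay, with a stated time of 48 h; a lower number here means a stronger inhibitor of growth, a higher number a weaker inhibitor of growth; of the two numbers so far, compound 1 `CC(=O)OC/C(=C\c1ccccc1)C(=O)c1ccccc1` gives 20000 nM, a gap within the scatter, so no order between them can be claimed. Compound 3 `CC(=O)OC/C(=C\c1ccccc1F)C(=O)c1ccccc1` is not yet measured. The change is 2-fluorophenyl in place of 4-fluorophenyl on a double-bonded chain carbon bound to a double-bonded chain carbon. For the measured compounds named here, the one measured step, a 1.3-fold higher number from compound 1 to compound 2 (0.10 log units; within the scatter), is the only guide; it stayed within the scatter and does not cover moving the fluorine, so no step beyond the scatter is expected in this assay. For compound 3 the estimated value is 22000 nM, in the range 9000 nM to 55000 nM. This means an expected step of a 1.1-fold lower number from compound 2 to compound 3 (0.06 log units; within the scatter).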

Compound 3, concentration for 50% growth inhibition: 22000 nM
Beside the measured number, compound 3's estimate shows no gap at the digits printed, within the range that was stated.
By their numbers in this assay, from the lowest: compounds 1, 3 and 2 (each within the scatter of the next).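

Moving the fluorine in this assay (a 1.1-fold lower number from compound 2 to compound 3 (0.06 log units; within the scatter)) does not separate 2-fluorophenyl from 4-fluorophenyl at this place, on a double-bonded chain carbon bound to a double-bonded chain carbon. Fluoro in place of hydrogen at the newly tested ring carbon (a 1.1-fold higher number from compound 1 to compound 3 (0.04 log units; within the scatter)) also leaves compound 3 within the scatter of compound 1. No evidence bearing on this result is available. Still open, on these data alone, is whether an amine or a carboxylic acid on this ring would give a step beyond the scatter.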